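A few compounds are considered here, and "the series" means these few. Any claim that something is new, unique, unknown or untested is made for them only; others in the source may bear on it.

Compound 1 `Cc1coc2c3c(ccc2c1=O)OC[C@H]1[C@@H]3Nc2ccccc2C1(C)C` gives 93800 nM in a functional assay on MDA-MB-231 cells (Homo sapiens) for antiproliferative activity, read by MTT assay; on this read-out lower numbers stand for stronger inhibition and higher numbers for weaker inhibition.
Compound 2 `Cc1ccc2c(c1)C(C)(C)[C@H]1COc3ccc4c(=O)c(C)coc4c3[C@H]1N2` gives only a limit in this assay, namely > 100000 nM.
Compound 3 `Cc1oc2c3c(ccc2c(=O)c1-c1ccccc1)OC[C@H]1[C@@H]3Nc2ccccc2C1(C)C` gives only a limit in this assay, namely > 100000 nM.

Compound 2 arises from compound 1 by one change, (methyl in place of hydrogen on an aromatic carbon), and in this assay this produced an at least 1.0-fold higher number from compound 1 to compound 2 (0.02 log units; that floor lies within the scatter). How the core of compound 3 differs from the core of compound 1 is not broken down here. Compound 4 `Cc1ccc2c(c1)C(C)(C)[C@H]1COc3ccc4c(=O)c(-c5ccccc5)c(C)oc4c3[C@H]1N2` has not yet been measured; it arises from compound 3 by the same change, (methyl in place of hydrogen on an aromatic carbon), at a place described in the same words. Resting on an at least 1.0-fold higher number from compound 1 to compound 2 (0.02 log units; that floor lies within the scatter) and on (the limit of > 100000 nM in this assay, at which 2 of the 3 values shown sit), a similarly small step is expected, a step that the limit leaves unreadable from compound 3 to compound 4. Compound 4 is therefore estimated to give 150000 nM in this assay, and it is expected that only a limit will be reported.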

Compound 4, half-maximal inhibitory concentration: > 100000 nM
Compound 4 ended at the assay's limit; the forecaster's own chance of this, stated with the estimate: 85%; the middle value is on the limit's open side.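

Compound 3 and compound 4 both give only a limit, not a number, so no step between them can be read: the limit of > 100000 nM in this assay, at which 3 of the 4 values shown sit.

The compounds shown leave open how strongly compound 2, compound 3 and compound 4 really act in this assay, and so whether the methyl changes anything.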